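Changing the Amide Substituent from Compound 3 to Compound 4

The source may hold more compounds than are shown below. What is called first, only, known or untested is meant among the compounds shown, and "the series" means these compounds.

Three measured compounds share one core and differ only in the group on the carbonyl carbon. Compound 1 `CCC(C)NC(=O)/C=C/c1c(/C=C/c2ccc(OC)cc2)cc(OC)cc1OC` gives 3950 nM in a functional assay on A549 cells (Homo sapiens) for inhibition, read by MTT assay, with a stated time of 48 h; on this read-out higher numbers stand for weaker inhibition and lower numbers for stronger inhibition. Compound 2 `CCCCNC(=O)/C=C/c1c(/C=C/c2ccc(OC)cc2)cc(OC)cc1OC` gives 1880 nM in this assay, and compound 3 `COc1ccc(/C=C/c2cc(OC)cc(OC)c2/C=C/C(=O)N(CC(C)C)CC(C)C)cc1` gives 3350 nM in this assay. Compound 3 thus holds the second highest of the three numbers; its value and that of compound 1 lie within the scatter of each other, and the same holds for compound 3 and compound 2. Compound 4 `COc1ccc(/C=C/c2cc(OC)cc(OC)c2/C=C/C(=O)N2CCC(Cl)CC2)cc1` differs from compound 3 in one place: 4-chloropiperidin-1-yl in place of diisobutylamino on a carbonyl carbon. The measured steps that bear on this change are all exchanges of the group on the carbonyl carbon: a 2.1-fold lower number from compound 1 to compound 2 (0.32 log units; beyond the scatter), a 1.2-fold lower number from compound 1 to compound 3 (0.07 log units; within the scatter) and a 1.8-fold higher number from compound 2 to compound 3 (0.25 log units; within the scatter). Only one of these went beyond the scatter, and only modestly, so no step beyond the scatter is expected in this assay for this change. The step expected from compound 3 to compound 4 is a 1.1-fold lower number from compound 3 to compound 4 (0.05 log units; within the scatter). Compound 4 is therefore estimated at 3000 nM, with a range from 1200 nM to 7500 nM.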

Compound 4, half-maximal inhibitory concentration: 2080 nM
Compound 4: middle estimate off by 1.4-fold (0.16 log units), on the high side, within the range that was stated.
By their numbers in this assay, from the lowest: compounds 2, 4, 3 and 1 (each within the scatter of the next, the first and the last beyond it).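

In this assay, the carbonyl carbon carries a ring for the first time among these compounds, and exchanging diisobutylamino for 4-chloropiperidin-1-yl gives a 1.6-fold lower number from compound 3 to compound 4 (0.21 log units; within the scatter), so this ring with its chlorine reads like the open-chain group it replaces. The other two exchanges give a 1.1-fold higher number from compound 2 to compound 4 (0.04 log units; within the scatter) and a 1.9-fold lower number from compound 1 to compound 4 (0.28 log units; within the scatter), which places compound 4 within the scatter of both compound 1 and compound 2, although those two lie beyond the scatter of each other. Nothing given here accounts for this result.

As far as these compounds go, how a piperidine without the chlorine, a morpholine or a piperazine would read on this carbonyl carbon remains open. The same holds for a ring or chain carrying a free amine or a carboxylic acid.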